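Urea series: aza-heteroaryl swap at the amide-type nitrogen

The source may hold more compounds than are shown below. What is called first, only, known or untested is meant among the compounds shown, and "the series" means these compounds.

Measured so far in an ADME assay on microsomes from liver (Mus musculus) for metabolic stability, using NADPH, with a stated time of 60 min; a higher number here means faster removal of the compound, a lower number slower removal:
- compound 1 `O=C(Nc1ccc(F)c(C(F)(F)F)c1)Nc1cnccn1`: 160 uL/min
- compound 2 `O=C(Nc1ccnc(C(F)(F)F)c1)Nc1ccc(F)c(C(F)(F)F)c1`: < 7 uL/min
- compound 3 `Cc1cc(NC(=O)Nc2ccc(F)c(C(F)(F)F)c2)on1`: 108 uL/min

Among the measured compounds shown here, compound 3 stands alongside compound 1, the only other numeric value: the step of a 1.5-fold lower number from compound 1 to compound 3 (0.17 log units; within the scatter) is within the scatter, so the two are not separated. The remaining value belongs to compound 2 and is a limit of this assay, (the limit of < 7 uL/min in this assay, at which 1 of the 3 values shown sits), not a number.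

The next compound, compound 4 `O=C(Nc1ccncc1)Nc1ccc(F)c(C(F)(F)F)c1`, is not yet measured. Its difference from compound 3 is pyridin-4-yl in place of 3-methyl-1,2-oxazol-5-yl on an amide-type nitrogen. For the measured compounds named here, the only measured step that touches the same position is a 1.5-fold lower number from compound 1 to compound 3 (0.17 log units; within the scatter), which shows that exchanging one small aromatic heterocycle for another at this nitrogen left this assay within the scatter. Compound 4 carries a six-membered ring with one nitrogen, a ring type shared with compound 1 and compound 2; compound 1 gave a number in the same region as compound 3, while compound 2 gave only a limit. Going by the values given here, no measured step joins compound 2 to compound 4, so its limit is noted without further weight.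

Compound 4 is therefore expected to stay close to compound 3, with the step of a 1.0-fold higher number from compound 3 to compound 4 (0.01 log units; within the scatter) expected to lie within the scatter. The estimate for compound 4 is 110 uL/min, with a range from 35 uL/min to 330 uL/min.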

Compound 4, intrinsic clearance in a liver preparation (reported as CLH), per the amount of preparation that the assay uses: 37 uL/min
Compound 4: middle estimate off by 3.0-fold (0.47 log units), on the high side; the range from low to high includes it.
By their numbers in this assay, from the lowest: compound 4; then compounds 3 and 1 (each within the scatter of the next). At a limit, below all of these: compound 2.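

In this assay, the ring on this amide-type nitrogen does make a difference: pyridin-4-yl gives a 2.9-fold lower number from compound 3 to compound 4 (0.47 log units; beyond the scatter) and a 4.3-fold lower number from compound 1 to compound 4 (0.64 log units; beyond the scatter), while the earlier exchange, a 1.5-fold lower number from compound 1 to compound 3 (0.17 log units; within the scatter), did not separate 3-methyl-1,2-oxazol-5-yl from pyrazin-2-yl. A second change also registers, with hydrogen in place of trifluoromethyl on an aromatic carbon giving an at least 5.2-fold higher number from compound 2 to compound 4 (0.72 log units; beyond the scatter), so a substituent on the six-membered ring counts as well as the identity of the ring. Compound 2 stands at a limit and not at a number, so this step fixes only a minimum size: the limit of < 7 uL/min in this assay, at which 1 of the 4 values shown sits.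

With so few rings at this nitrogen and a single substituent change, the data do not tell whether the lower number of compound 4 belongs to the pyridin-4-yl ring as such or to some feature it shares with other rings, and no cause can be assigned. Also open, from the compounds shown here alone, is where a methoxy group or an amine on that same aromatic carbon would fall relative to compound 4 and to the limit of compound 2.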